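Swapping a fluorinated aryl for cyclohexyl on the amide

A few compounds are considered here, and "the series" means these few. Any claim that something is new, unique, unknown or untested is made for them only; others in the source may bear on it.

In a physicochemical assay for lipophilicity, using the shake flask method, in phosphate buffer, measured as octanol-water partition, at pH 7.4 (a lower number here means a more polar compound, a higher number a more lipophilic compound), compound 2 `COc1cc(-c2cc(C(=O)O)c3ccccc3n2)ccc1OCC(=O)Nc1ccccc1C(F)(F)F` gives 1.3, the lower of two numbers; compound 1 `COc1cc(-c2cc(C(=O)O)c3ccccc3n2)ccc1OCC(=O)Nc1ccc(Cl)cc1` gives 1.5, and the change a number 0.20 log units lower from compound 1 to compound 2 (within the scatter) lies within the scatter. Compound 3 `COc1cc(-c2cc(C(=O)O)c3ccccc3n2)ccc1OCC(=O)NC1CCCCC1` differs by cyclohexyl in place of 2-(trifluoromethyl)phenyl on an amide-type nitrogen. For the measured compounds named here, only one measured step exists, and it exchanges one aryl group for another, so no measured step covers an aryl-to-cycloalkyl change. With nothing pointing either way, a step of no change at the digits printed from compound 2 to compound 3 (within the scatter) is expected, no larger than the scatter. Compound 3 is therefore estimated at 1.3, between 0.7 and 1.9.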

Compound 3, distribution coefficient: 0.8
The estimate for compound 3 lay 0.50 log units above the measured number; low and high end bracket the measured number.
By their numbers in this assay, from the lowest: compound 3; then compounds 2 and 1 (each within the scatter of the next).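

In this assay, putting cyclohexyl on the amide nitrogen in place of either aryl group gives a number 0.50 log units lower from compound 2 to compound 3 (beyond the scatter) and a number 0.70 log units lower from compound 1 to compound 3 (beyond the scatter). The two aryl groups stayed within the scatter of each other, so the number at this position responds to this exchange of an aromatic ring for a non-aromatic one, not to the aryl swap. No measurement shown here accounts for the step.

Open, as far as these compounds go, is how a plain phenyl group would read, which would separate the ring change from the loss of the chlorine or trifluoromethyl. Also open, from the compounds shown here alone, is how a smaller ring such as cyclopropyl or an open chain such as butyl would read on this nitrogen.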